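Methoxy beside the phenol: compound 4 in the A-375 series

The compounds below may be only part of what the source reports. "The series", "measured", "known", "first", "only" and "open" are said of these compounds alone.

The series is built on a shared core of two secondary alcohols flanked by two phenylethyl arms. Compound 1 `O[C@@H](CCc1ccccc1)C[C@@H](O)CCc1ccccc1` and compound 2 `O[C@H](CCc1ccccc1)C[C@@H](O)CCc1ccccc1` are the same in every atom and bond and differ only in the configuration as drawn (the fact that compounds 1 and 2 differ only in the configuration as drawn). In a functional assay on A-375 cells (Homo sapiens) for antiproliferative activity, read by MTT assay, with a stated time of 48 h (on this read-out lower numbers stand for stronger inhibition and higher numbers for weaker inhibition), compound 1 gives 148 ug/mL, and compound 2 gives 164 ug/mL; the step of a 1.1-fold higher number from compound 1 to compound 2 (0.04 log units; within the scatter) is within the scatter. For the measured compounds named here, compound 3 `Oc1ccc(CC[C@@H](O)C[C@@H](O)CCc2ccccc2)cc1` carries a hydroxy group on one aromatic ring, and in this assay compound 3 gives 57.8 ug/mL, the lowest of the three numbers; the step of a 2.8-fold lower number from compound 2 to compound 3 (0.45 log units; beyond the scatter) is the only change in the set that moved the number beyond the scatter.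

Compound 4 `COc1cc(CC[C@@H](O)C[C@@H](O)CCc2ccccc2)ccc1O` is the next step from compound 3: methoxy in place of hydrogen on an aromatic carbon. Going by the values given here, the nearest precedent is the hydroxy step from compound 2 to compound 3, which was modest; a methoxy group is a different substituent, and the data hold no second example of a group entering the aromatic ring. A shift of modest size is therefore expected at most, plausibly again toward lower numbers, but it may equally stay within the scatter.

Compound 4 is expected to give about 45 ug/mL in this assay, with a range from 20 ug/mL to 110 ug/mL, meaning an expected step of a 1.3-fold lower number from compound 3 to compound 4 (0.11 log units; within the scatter).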

Compound 4, half-maximal inhibitory concentration: 75.2 ug/mL
For compound 4 the middle estimate is 1.7-fold (0.22 log units) below the measured one, and the stated range covers the measured number.
By their numbers in this assay, from the lowest: compounds 3, 4, 1 and 2 (each within the scatter of the next, the first and the last beyond it).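

Methoxy in place of hydrogen, on an aromatic carbon ortho to a hydroxy group, gives a 1.3-fold higher number from compound 3 to compound 4 (0.11 log units; within the scatter) in this assay, so this position accepts the added group without a change that can be told from the scatter. For the compounds shown here, the earlier compounds showed only a hydroxy group entering the ring, with a 2.8-fold lower number from compound 2 to compound 3 (0.45 log units; beyond the scatter), and that step lay beyond the scatter; compound 4 is the first case of a further group on a ring that already carries the hydroxy group, and here the number does not move measurably. Nothing in the data shown offers a reason for this step.

On these data alone, whether the position would respond in the same way to other groups remains open, for instance to an amine, a carboxylic acid or a longer chain on the oxygen in place of methoxy, as does whether methoxy would behave alike on a ring without the hydroxy group. Also open, as far as these compounds go, is whether the change in configuration seen between compound 1 and compound 2, which stayed within the scatter, would stay so in compounds carrying these ring groups.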